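This account rests on a few compounds, and the source may have more. Where it says the series, first, only, none or still open, it means among the compounds named here.

Compound 1 `Cn1cc(-c2ccc(C(F)(F)F)cc2)c2cc(F)c(C(=O)NS(=O)(=O)C3CC3)cc21`: 27 nM
Compound 2 `CC(C)COc1ncc(-c2cn(C)c3cc(C(=O)NS(=O)(=O)C4CC4)c(F)cc23)cc1Cl`: 10 nM
Compound 3 `CC(C)COc1ccc(-c2cn(C)c3cc(C(=O)NS(C)(=O)=O)c(F)cc23)cn1`: 115 nM

All three were tested in an assay on HEK293 cells for inhibition of sodium channel protein type 9 subunit alpha (Mus musculus), read by patch clamp; on this read-out higher numbers stand for weaker inhibition and lower numbers for stronger inhibition. Compound 3 gives the highest number of the three, so it is the weakest inhibitor among them: compound 1 stands well below it, and compound 2 further still, both gaps wider than the usual scatter. Compound 4 `CC(C)COc1ccc(-c2cn(C)c3cc(C(=O)NS(=O)(=O)C4CC4)c(F)cc23)cn1` has not yet been measured. It differs from compound 3 in one place: cyclopropyl in place of methyl on a sulfonyl sulfur. For the measured compounds named here, no pair of measured compounds differs by a single change, so there is no directly comparable step. Still, both measured compounds that carry the cyclopropyl on the sulfonyl sulfur sit lower; compound 1 gives 27 nM and compound 2 gives 10 nM, while compound 3 with the methyl gives 115 nM. Other parts of these molecules differ as well, so that gap is not a clean reading of the sulfonyl change alone. The step from compound 3 to compound 4 is therefore expected to lower the number by a moderate amount, a 2.9-fold lower number from compound 3 to compound 4 (0.46 log units; beyond the scatter). Compound 4 is estimated at 40 nM, within a range from 15 nM to 120 nM.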

Compound 4, half-maximal inhibitory concentration: 37 nM
Compound 4: middle estimate off by 1.1-fold (0.03 log units), on the high side, and the stated range covers the measured number.
By their numbers in this assay, from the lowest: compound 2; then compounds 1 and 4 (each within the scatter of the next); then compound 3.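

In this assay, cyclopropyl in place of methyl on a sulfonyl sulfur, with the rest of the molecule unchanged, gives a 3.1-fold lower number from compound 3 to compound 4 (0.49 log units; beyond the scatter), so this change can now be read on its own rather than through compounds that also differ elsewhere. A second single change can also be read: hydrogen in place of chloro on an aromatic carbon gives a 3.7-fold higher number from compound 2 to compound 4 (0.57 log units; beyond the scatter), which shows that removing the chloro raises the number on this cyclopropyl background. Nothing measured here explains why either change moves the number.

As far as these compounds go, each change is seen only once, so it remains open whether the sulfonyl step would be the same size with the chloro present. The compounds shown also leave open what an ethyl on the sulfonyl sulfur, or a bromo or nitrile in place of the chloro, would do.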